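Benzyloxycarbonyl for trifluoromethyl on the fluorophenyl core

A few compounds are considered here, and "the series" means these few. Any claim that something is new, unique, unknown or untested is made for them only; others in the source may bear on it.

Compound 1 `FC(F)(F)c1ccc2[nH]c(-c3cn(-c4ccccc4)nc3-c3ccccc3)nc2c1` serves as the reference. In a functional assay on MCF7 cells (Homo sapiens) for antiproliferative activity, read by MTT assay, with a stated time of 48 h (on this read-out higher numbers stand for weaker inhibition and lower numbers for stronger inhibition), compound 1 gives 2660 nM. Compound 2 `O=C(OCc1ccccc1)c1ccc2[nH]c(-c3cn(-c4ccccc4)nc3-c3ccccc3)nc2c1` differs from it by benzyloxycarbonyl in place of trifluoromethyl on an aromatic carbon; in this assay compound 2 gives 12600 nM, a step of a 4.7-fold higher number from compound 1 to compound 2 (0.68 log units; beyond the scatter). Compound 3 `Fc1ccc(-c2nn(-c3ccccc3)cc2-c2nc3cc(C(F)(F)F)ccc3[nH]2)cc1` differs from compound 1 by fluoro in place of hydrogen on an aromatic carbon; in this assay compound 3 gives 2130 nM, a step of a 1.2-fold lower number from compound 1 to compound 3 (0.10 log units; within the scatter), so compound 1 and compound 3 cannot be told apart on this read-out. Between compound 3 and compound 2 the gap lies beyond the scatter.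

Compound 4 `O=C(OCc1ccccc1)c1ccc2[nH]c(-c3cn(-c4ccccc4)nc3-c3ccc(F)cc3)nc2c1` is not yet measured. It differs from compound 3 by benzyloxycarbonyl in place of trifluoromethyl on an aromatic carbon. The change from compound 1 to compound 2 and the change from compound 3 to compound 4 are the same change at the same place; the two cores differ only by fluoro in place of hydrogen on an aromatic carbon, a difference that left the number within the scatter. This single precedent is the whole basis for what follows. Among the compounds with values here, for compound 4 the expected step is a 4.7-fold higher number from compound 3 to compound 4 (0.67 log units; beyond the scatter), because a 4.7-fold higher number from compound 1 to compound 2 (0.68 log units; beyond the scatter) is the one measured instance of this change and the core difference did not move the number. For compound 4 the estimate in this assay is 10000 nM, with a range from 4000 nM to 25000 nM. One precedent only; the range is kept wide.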

Compound 4, half-maximal inhibitory concentration: 9240 nM
Estimate against measurement, compound 4: 1.1-fold (0.03 log units) above; measured number inside the range.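

In this assay, benzyloxycarbonyl in place of trifluoromethyl on the fluoro-bearing core gives a 4.3-fold higher number from compound 3 to compound 4 (0.64 log units; beyond the scatter), and this step matches the one seen on the core of compound 1: the same change on two cores in this assay, a 4.7-fold higher number (0.68 log units; beyond the scatter) from compound 1 to compound 2 and a 4.3-fold higher number (0.64 log units; beyond the scatter) from compound 3 to compound 4, 1.1-fold (0.04 log units) apart, within the scatter of two such steps

Read the other way round the same four compounds, fluoro in place of hydrogen gives a 1.4-fold lower number from compound 2 to compound 4 (0.13 log units; within the scatter), so the fluoro leaves the number within the scatter with either group in place: the same change on two cores in this assay, a 1.2-fold lower number (0.10 log units; within the scatter) from compound 1 to compound 3 and a 1.4-fold lower number (0.13 log units; within the scatter) from compound 2 to compound 4, 1.1-fold (0.04 log units) apart, within the scatter of two such steps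

This shows that the change carries between these two cores, which differ by one fluoro only; it does not show that the change would carry to a core that differs more, and it gives no reason for the size of the step.

Still open, going by these compounds, is whether the higher number follows the carbonyl or the added aromatic ring of benzyloxycarbonyl, which a carboxylic acid or a methyl ester at the same place would help to separate. Also open, on these data alone, is whether the step keeps its size with a chloro or a methoxy group in place of the fluoro.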